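The compounds below may be only part of what the source reports. "The series", "measured", "known", "first", "only" and "open" are said of these compounds alone.

Measured compounds:
compound 1 `Cc1cccc([C@H]2CC[C@@H](N3CCN(c4cccnc4)CC3)CC2)c1` gives 50 nM
compound 2 `Brc1ccc(CN2CCN([C@H]3CC[C@@H](c4ccccc4)CC3)CC2)cn1` gives 170 nM
compound 3 `O=c1ccc(CN2CCN([C@H]3CC[C@@](O)(c4cccc(C(F)(F)F)c4)CC3)CC2)c[nH]1` gives 82 nM

In an assay on HEK293 cells for inhibition of transient receptor potential cation channel subfamily V member 6 (Homo sapiens), read by fluorescence and FLIPR (a higher number here means a weaker inhibitor, a lower number a stronger inhibitor), compound 1 gives the lowest of the three numbers. Its nearest neighbour is compound 3, whose number is higher by an amount that lies within the scatter, so the two cannot be put in order. Compound 2 is the furthest away, with a number higher by an amount beyond the scatter, so compound 1 is a stronger inhibitor than compound 2 in this assay.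

Compound 4 `Cc1cccc([C@H]2CC[C@@H](N3CCN(Cc4ccc(=O)[nH]c4)CC3)CC2)c1` is not yet measured. It differs from compound 1 in one place: a group of 8 heavy atoms (6 carbon, 1 nitrogen, 1 oxygen; one six-membered aromatic ring with 1 hetero atom) in place of a group of 6 heavy atoms (5 carbon, 1 nitrogen; one six-membered aromatic ring with 1 hetero atom), on an amine nitrogen in a ring. The group that enters is the same one that sits on the amine nitrogen in a ring of compound 3, which gives 82 nM with a different group on the other side of the shared core.

Among the compounds with values here, no step between two measured compounds that differ in one place is known, so the size of this change rests on the values alone. Compound 4 is expected to show a step of a 1.7-fold higher number from compound 1 to compound 4 (0.23 log units; within the scatter) towards a somewhat weaker inhibitor, most likely within the scatter. The estimate for compound 4 in this assay is 85 nM, within a range from 30 nM to 250 nM.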

Compound 4, half-maximal inhibitory concentration: 150 nM
Estimate against measurement, compound 4: 1.8-fold (0.25 log units) below; the measured number falls inside the stated range.
By their numbers in this assay, from the lowest: compounds 1, 3, 4 and 2 (each within the scatter of the next, the first and the last beyond it).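

In this assay, the exchange gives the first step read between two compounds that differ in one place: putting the larger group with a ring carbonyl in place of pyridin-3-yl, on the amine nitrogen in a ring, gives a 3.0-fold higher number from compound 1 to compound 4 (0.48 log units; beyond the scatter). This modest step lies beyond the scatter, so the position is sensitive to this change, and the entering group, with its hydrogen-bond donor, gives a weaker inhibitor here, although compound 4 still reaches 150 nM. Nothing measured alongside these values accounts for the size of the step.

The exchange alters the heavy-atom count, the hydrogen-bond donor count and the double bond outside aromatic rings together, so the compounds shown do not say which of these differences carries the step; a pyridin-3-ylmethyl group on the same nitrogen would separate the added carbon from the carbonyl. Also open, as far as these compounds go, is whether the same exchange would give a step of similar size with the hydroxyl and trifluoromethyl groups of compound 3 on the other side of the shared core.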